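From 2-fluorophenyl to 3-nitrophenyl: a small change expected

The compounds below may be only part of what the source reports. "The series", "measured", "known", "first", "only" and "open" are said of these compounds alone.

In a functional assay on HepG2 cells (Homo sapiens) for cytotoxicity, read by MTT assay, with a stated time of 24 h (a lower number here means a stronger inhibitor, a higher number a weaker inhibitor), compound 1 `COc1cc(/C=C2\CN(C)C/C(=C\c3ccccc3F)C2=O)cc(OC)c1` gives 1240 nM and compound 2 `CN1C/C(=C\c2cccc([N+](=O)[O-])c2)C(=O)/C(=C/c2ccccc2F)C1` gives 1080 nM as its reading. Among the measured compounds shown here, these two numbers lie within the usual scatter of each other, so compound 1 stands level with the only other measured compound.

Compound 3 `COc1cc(/C=C2\CN(C)C/C(=C\c3cccc([N+](=O)[O-])c3)C2=O)cc(OC)c1` has not been measured yet. It keeps the core of compound 1 but has 3-nitrophenyl in place of 2-fluorophenyl on a double-bonded chain carbon bound to a double-bonded ring carbon on a double-bonded chain carbon bound to a double-bonded ring carbon.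

Compound 2 also carries 3-nitrophenyl and gives 1080 nM as its reading, so no shift beyond the scatter is expected in this assay for this swap. The estimated 1.1-fold lower number from compound 1 to compound 3 (0.05 log units; within the scatter) is therefore small. For compound 3 the expected value is 1100 nM with an estimated range from 500 nM to 2400 nM as a rough guide.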

Compound 3, half-maximal inhibitory concentration: 1840 nM
Compound 3: the middle estimate sits 1.7-fold (0.22 log units) below what was measured; low and high end bracket the measured number.
By their numbers in this assay, from the lowest: compounds 2, 1 and 3 (each within the scatter of the next).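

In this assay, the swap at this position, on a double-bonded chain carbon bound to a double-bonded ring carbon, gives a 1.5-fold higher number from compound 1 to compound 3 (0.17 log units; within the scatter). This is the first pair shown that differs in one place only, so it shows directly that, on the core of compound 1, 3-nitrophenyl can stand in place of 2-fluorophenyl without moving the reading beyond the usual scatter. No measurement is available that would explain this result.

From the compounds shown here alone, both groups compared here are phenyl rings, so it remains open whether this position would respond to a different kind of group, such as an amine, a carboxylic acid or a longer carbon chain. Going by these compounds, it also remains open whether an unsubstituted phenyl ring would give a reading level with these two.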